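The source may report more compounds than this note shows. Statements on the series, on what has been measured and on what is new or still open speak of the compounds shown alone.

Compound 1 `c1ccc(Cn2cncc2CNc2cccc(-c3ccccc3)c2)cc1` was tested in a toxicity assay on NIH3T3 cells (Mus musculus) for cytotoxicity, read by resazurin assay; a higher number here means that more compound is needed for the effect, a lower number that less compound is needed. In this assay compound 1 gives > 750 nM, which is a limit of the assay rather than a number. Compound 2 `c1ccc(-c2ccc(Cn3cncc3CNc3cccc(-c4ccccc4)c3)cc2)cc1` gives 10000 nM, and compound 3 `Clc1ccc(Cn2cncc2CNc2cccc(-c3ccccc3)c2)cc1` gives 10000 nM. The steps a step that the limit leaves unreadable from compound 1 to compound 2 and a step that the limit leaves unreadable from compound 1 to compound 3 cannot be sized because the limit of > 750 nM in this assay, at which 1 of the 3 values shown sits, hides where compound 1 truly sits, while no change at the digits printed from compound 2 to compound 3 (within the scatter) shows no change beyond the scatter. Compound 4 `c1ccc(Cn2cncc2CNc2cccc(-c3cccnc3)c2)cc1` differs from compound 1 by pyridin-3-yl in place of phenyl on an aromatic carbon. Among the measured compounds shown here, none of the measured steps touches this part of the molecule, so no measured step bears directly on it. For compound 4 the expected step is a step that the limit leaves unreadable from compound 1 to compound 4. Compound 4 is estimated at 10000 nM, with a range from 2500 nM to 40000 nM.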

Compound 4, half-maximal effective concentration: > 1000 nM
Compound 4: a limit, no number; the forecaster's own chance of this, stated with the estimate: 60%; the middle value is on the limit's open side.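

Compound 1 and compound 4 each carry only a limit of the assay, not a number, so the step between them cannot be read. The compounds shown leave open whether pyridin-3-yl in place of phenyl changes the result in this assay at all.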